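The source may report more compounds than this note shows. Statements on the series, on what has been measured and on what is new or still open speak of the compounds shown alone.

Working notes on the series: compound 1 (`COc1ccc(S(=O)(=O)N2CCc3cccc(-c4ccc([N+](=O)[O-])cc4)c32)cc1`), compound 2 (`COc1ccc(S(=O)(=O)N2CCc3cccc(-c4ccc(F)cc4)c32)cc1`) and compound 3 (`COc1ccc(S(=O)(=O)n2ccc3cccc(-c4ccc(C#N)cc4)c32)cc1`) have been measured, while compound 4 (`COc1ccc(S(=O)(=O)N2CCc3cccc(-c4ccc(C#N)cc4)c32)cc1`) has not. In a functional assay on MKN-45 cells (Homo sapiens) for inhibition, with a stated time of 72 h (a higher number here means a weaker inhibitor, a lower number a stronger inhibitor), compound 2 gives 79 nM. In the same read-out compound 1 gives 34 nM and compound 3 gives 143 nM. Compound 2 thus lies within the scatter of compound 3 and beyond the scatter of compound 1, with the higher number of that pair.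

The change to compound 4 is cyano in place of fluoro on an aromatic carbon, para to a large group. For the measured compounds named here, only one measured step bears directly on this place on the same core: a 2.3-fold higher number from compound 1 to compound 2 (0.37 log units; beyond the scatter), modest and beyond the scatter. Compound 3 also carries cyano, but its core differs, so it gives no clean comparison. Treating cyano like the nitro of compound 1 is an untested assumption, and it points to a modest move towards a lower number in this assay. The expected change is a 1.8-fold lower number from compound 2 to compound 4 (0.24 log units; within the scatter). For compound 4 the estimated value is 45 nM, with an expected range of 20 nM to 100 nM.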

Compound 4, half-maximal inhibitory concentration: 17.2 nM
Estimate against measurement, compound 4: 2.6-fold (0.42 log units) above; measured number outside the range, below it.
By their numbers in this assay, from the lowest: compounds 4 and 1 (each within the scatter of the next); then compounds 2 and 3 (each within the scatter of the next).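

On the shared core, the change from 4-fluorophenyl to 4-cyanophenyl, on an aromatic carbon para to a large group, gives a 4.6-fold lower number from compound 2 to compound 4 (0.66 log units; beyond the scatter) in this assay. For the compounds shown here, until now, the only measured step at this place was the one between nitro and fluoro; this result shows that a second group, cyano, also stands apart from fluoro beyond the scatter. Cyano and nitro cannot be separated in this read-out, with a 2.0-fold lower number from compound 1 to compound 4 (0.30 log units; within the scatter), so of the three groups compared on this core, only fluoro stands apart.

Going by these compounds, whether this holds for other groups at this place, such as an amine or a carboxylic acid, remains open. No supporting evidence accompanies these values.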